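The compounds below may be only part of what the source reports. "The series", "measured", "known", "first", "only" and "open" are said of these compounds alone.

Measured compounds:
- compound 1, `COc1ccc2c(OCC[C@@H]3NC(=O)N(C)CCCC/C=C\[C@@H]4C[C@@]4(C(=O)NS(=O)(=O)C4(F)CC4)NC3=O)cc(-c3nc(C(C)C)cs3)nc2c1Cl`: 51400 nM
- compound 2, `COc1ccc2c(OCC[C@@H]3NC(=O)N(C)CCCC/C=C\[C@@H]4C[C@@]4(C(=O)NS(=O)(=O)C4(C)CC4)NC3=O)cc(-n3ccc(C(C)C)n3)nc2c1C`: 25600 nM

Both values come from an ADME assay on cells (Homo sapiens) for activation; a higher number here means that more compound is tolerated, a lower number that less compound is tolerated. Compound 2 holds the lower of the two numbers, yet the gap to compound 1 is within the scatter, so the two compounds cannot be told apart on this reading; compound 1 gives 51400 nM and compound 2 gives 25600 nM.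

Compound 3, `CCCn1cc(-c2cc(OCC[C@@H]3NC(=O)N(C)CCCC/C=C\[C@@H]4C[C@@]4(C(=O)NS(=O)(=O)C4(C)CC4)NC3=O)c3ccc(OC)c(C)c3n2)cn1`, is not yet measured. Its difference from compound 2 is a rearrangement: 1-propyl-1H-pyrazol-4-yl in place of 3-isopropyl-1H-pyrazol-1-yl on an aromatic carbon. The atoms are the same; the pyrazole ring is simply attached through a different ring atom, with the propyl chain now on the ring nitrogen instead of an isopropyl group on a ring carbon. For the measured compounds named here, no measured pair in this set shows what such a swap does in this assay, so the expectation rests on the two values alone, which sit close together despite larger differences between compound 1 and compound 2. On that basis the step from compound 2 to compound 3 is expected to be small, a 1.2-fold higher number from compound 2 to compound 3 (0.07 log units; within the scatter), and not beyond the scatter in either direction. Compound 3 is therefore estimated at 30000 nM, with a plausible range from 12000 nM to 70000 nM.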

Compound 3, half-maximal cytotoxic concentration: 62300 nM
Estimate against measurement, compound 3: 2.1-fold (0.32 log units) below; the measured number falls inside the stated range.
By their numbers in this assay, from the lowest: compounds 2, 1 and 3 (each within the scatter of the next, the first and the last beyond it).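

In this assay, for the compounds shown here, putting 1-propyl-1H-pyrazol-4-yl in place of 3-isopropyl-1H-pyrazol-1-yl on the same aromatic carbon gives a 2.4-fold higher number from compound 2 to compound 3 (0.39 log units; beyond the scatter), the first change in this set that can be read in one place. The two groups match in their heavy atoms, their five-membered aromatic ring and their counts of hydrogen-bond donors and acceptors; they differ in how the pyrazole is attached and in the form and placing of the three-carbon chain, and that rearrangement alone moves the number a modest distance beyond the scatter. No measurement shown here accounts for this shift.

This single step joins two changes together, so it leaves open whether the new attachment of the pyrazole or the switch from isopropyl to propyl carries the difference, a question that 1-isopropyl-1H-pyrazol-4-yl would address. As far as these compounds go, how a longer chain, as in 1-butyl-1H-pyrazol-4-yl, or a pyrazole bearing a carboxylic acid would read in this assay also stays open.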